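A thiophene replaces naphthalene on the shared core

This account rests on a few compounds, and the source may have more. Where it says the series, first, only, none or still open, it means among the compounds named here.

Measured so far:
Compound 1 `Brc1cn2ccnc2c(-c2ccc3ncn(C4CCCCC4)c3c2)n1` gives 5.21% in a functional assay on HT-29 cells (Homo sapiens) for inhibition, read by sulforhodamine B assay, with a stated time of 48 h, tested at 10 uM; a higher number here means more inhibition at the concentration tested (going by the name of the read-out), a lower number less inhibition.
Compound 2 `COc1ccc(-c2cn3ccnc3c(-c3ccc4ncn(C5CCCCC5)c4c3)n2)cc1` gives 92.5% in this assay.
Compound 3 `c1ccc2c(-c3cn4ccnc4c(-c4ccc5ncn(C6CCCCC6)c5c4)n3)cccc2c1` gives 4.11% in this assay.

Compound 3 has the lowest of the three numbers. Its nearest neighbour is compound 1, a step that lies within the scatter, and its furthest is compound 2, a step well beyond it. The next compound, compound 4 `c1cn2cc(-c3ccsc3)nc(-c3ccc4ncn(C5CCCCC5)c4c3)c2n1`, differs from compound 3 in one place: thiophen-3-yl in place of naphthalen-1-yl on an aromatic carbon.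

Among the measured compounds shown here, two measured steps bear on this. The change from bromo to naphthalen-1-yl gave a number 1.1 percentage points lower from compound 1 to compound 3 (within the scatter), while the change from 4-methoxyphenyl to naphthalen-1-yl gave a number 88.4 percentage points lower from compound 2 to compound 3 (beyond the scatter). So the group at this position can swing the read-out across almost its whole range, and nothing measured so far contains thiophen-3-yl. The expectation is therefore broad: compound 4 is estimated at 35%, with a range from 2% to 85%. This expected step is a number 30.9 percentage points higher from compound 3 to compound 4 (beyond the scatter).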

Compound 4, a percentage reported as inhibition, at one concentration (the size of the read-out at that concentration, not a potency): 5.68%
For compound 4 the middle estimate is 29.3 percentage points above the measured one, and the stated range covers the measured number.
By their numbers in this assay, from the lowest: compounds 3, 1 and 4 (each within the scatter of the next); then compound 2.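

At this position, replacing naphthalen-1-yl with thiophen-3-yl gives a number 1.6 percentage points higher from compound 3 to compound 4 (within the scatter) in this assay, and replacing bromo with thiophen-3-yl gives a number 0.5 percentage points higher from compound 1 to compound 4 (within the scatter), so neither change can be told apart from repeat-measurement noise. Bromo, naphthalen-1-yl and thiophen-3-yl therefore all sit at the same low level, even though they differ widely in size and ring type, while replacing 4-methoxyphenyl with thiophen-3-yl gives a number 86.8 percentage points lower from compound 2 to compound 4 (beyond the scatter), leaving compound 2 as the one exception among these four compounds. No measurement shown here offers a reason for this split.

The compounds shown leave open whether the high value of compound 2 depends on the methoxy group or on the phenyl ring that carries it. As far as these compounds go, a plain phenyl group would help separate these two parts, and an amine at this position remains untested territory in this set.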